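A few compounds are considered here, and "the series" means these few. Any claim that something is new, unique, unknown or untested is made for them only; others in the source may bear on it.

Measured so far in a functional assay on P388 cells (Mus musculus) for cytotoxicity; on this read-out higher numbers stand for weaker inhibition and lower numbers for stronger inhibition:
- compound 1 `COC(=O)CC[C@@H]1NC(=O)[C@@H](C)NC(=O)[C@@H]2Cc3ccc(OC)c(c3)Oc3ccc(cc3)C[C@@H](C(=O)N2C)N(C)C(=O)[C@H](C)NC(=O)[C@H](Cc2ccc(OC)cc2)N(C)C1=O`: 58.9 nM
- compound 2 `COC(=O)C[C@@H]1NC(=O)[C@@H](C)NC(=O)[C@@H]2Cc3ccc(OC)c(c3)Oc3ccc(cc3)C[C@@H](C(=O)N2C)N(C)C(=O)[C@H](C)NC(=O)[C@H](Cc2ccc(OC)cc2)N(C)C1=O`: 41.7 nM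
- compound 3 `CCC[C@@H]1NC(=O)[C@@H](C)NC(=O)[C@@H]2Cc3ccc(OC)c(c3)Oc3ccc(cc3)C[C@@H](C(=O)N2C)N(C)C(=O)[C@H](C)NC(=O)[C@H](Cc2ccc(OC)cc2)N(C)C1=O`: 13.8 nM

Compound 3 has the lowest number of the three, and both of its steps lie beyond the scatter: a 4.3-fold lower number from compound 1 to compound 3 (0.63 log units; beyond the scatter) and a 3.0-fold lower number from compound 2 to compound 3 (0.48 log units; beyond the scatter). Compound 4 `C=C[C@@H]1NC(=O)[C@@H](C)NC(=O)[C@@H]2Cc3ccc(OC)c(c3)Oc3ccc(cc3)C[C@@H](C(=O)N2C)N(C)C(=O)[C@H](C)NC(=O)[C@H](Cc2ccc(OC)cc2)N(C)C1=O` has not yet been measured. It differs from compound 3 in a single place, with vinyl in place of propyl on a saturated ring carbon.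

Within the data shown here, no measured step makes this exchange. The two steps to compound 3 both remove methoxycarbonyl, a group that neither compound 3 nor compound 4 carries, so they bear on it only loosely. The closest parallel is the change from (methoxycarbonyl)methyl to methoxycarbonyl, a 1.4-fold lower number from compound 1 to compound 2 (0.15 log units; within the scatter), which stays within the scatter. A step beyond the scatter in this assay is therefore not expected, although the uncertainty is wide. The expected change is a 1.3-fold higher number from compound 3 to compound 4 (0.12 log units; within the scatter). The estimate for compound 4 is 18 nM, with an expected range from 6 nM to 50 nM.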

Compound 4, half-maximal inhibitory concentration: 25.7 nM
Compound 4: the middle estimate sits 1.4-fold (0.15 log units) below what was measured, and the stated range covers the measured number.
By their numbers in this assay, from the lowest: compounds 3, 4, 2 and 1 (each within the scatter of the next, the first and the last beyond it).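

In this assay this ring carbon accepts vinyl, with its double bond outside aromatic rings, in place of propyl: a 1.9-fold higher number from compound 3 to compound 4 (0.27 log units; within the scatter) is the step, so this shorter unsaturated group holds the number as closely as repeat measurements would. Against the groups bearing methoxycarbonyl the result splits, with a 1.6-fold lower number from compound 2 to compound 4 (0.21 log units; within the scatter) for vinyl in place of (methoxycarbonyl)methyl, but a 2.3-fold lower number from compound 1 to compound 4 (0.36 log units; beyond the scatter) for vinyl in place of 2-(methoxycarbonyl)ethyl as the only one of the three new steps that clears the scatter. Nothing available explains these numbers.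

The compounds shown leave open how an amine, a carboxylic acid or a chain longer than propyl on this ring carbon would read in this assay as a result. They also leave open whether a saturated ethyl group would read like vinyl, so the double bond cannot be told apart from chain length.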